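The source may report more compounds than this note shows. Statements on the series, on what has been measured and on what is new or still open speak of the compounds shown alone.

Compound 1 `Cc1nc(C(=O)NCc2ccccc2)c(O)c(=O)n1C` opens the set, and in an ADME assay on HepG2 cells (Homo sapiens) for cytotoxicity, in the presence of a further agent that is not named here (a lower number here means a stronger inhibitor, a higher number a weaker inhibitor), compound 1 gives only a limit of the assay, > 100000 nM, not a number. Compound 2 `CN(Cc1ccccc1)C(=O)c1nc(Cc2ccccc2C(F)(F)F)n(C)c(=O)c1O` likewise gives in this assay a limit of the assay, > 100000 nM. Compound 3 `Cn1c(Cc2ccccc2C(F)(F)F)nc(C(=O)NCc2ccccn2)c(O)c1=O` stands in the same place: in this assay compound 3 gives a limit of the assay, > 100000 nM, so its position among the three is known only as a limit, and the other two values shown are limits as well. For the measured compounds named here, the single measured step, a step that the two limits leave unreadable from compound 2 to compound 3, cannot be sized, because the limit of > 100000 nM in this assay, at which 3 of the 3 values shown sit, holds both of its ends.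

Compound 4 `Cn1c(Cc2ccccc2C(F)(F)F)nc(C(=O)NCc2ccccc2F)c(O)c1=O` is the next compound, differing from compound 3 by 2-fluorophenyl in place of pyridin-2-yl on a saturated chain carbon bound to an amide-type nitrogen. Going by the values given here, no measured step bears directly on this change, and the one step that exists is unreadable, so there is no ground to expect any movement beyond the scatter. For compound 4 the expected step is a number no higher from compound 3 to compound 4 (the limit leaves the size open). In this assay compound 4 is therefore estimated at 100000 nM, within a range from 50000 nM to 200000 nM, most likely reported again as a limit.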

Compound 4, half-maximal inhibitory concentration: > 100000 nM
Compound 4: only a limit was reported (the forecaster's own chance of this, stated with the estimate: 85%); the middle value sits exactly at the limit.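

Neither step to compound 4, from compound 2 or from compound 3, can be read, because each has a limit at both ends: the limit of > 100000 nM in this assay, at which 4 of the 4 values shown sit. The compounds shown leave open how any of them ranks in this assay, since none gives a number there.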